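Aryl Amide Swap on a Trimethoxyphenyl Triazole Core

This account rests on a few compounds, and the source may have more. Where it says the series, first, only, none or still open, it means among the compounds named here.

Compound 1 `CNC(=O)c1nc(-c2cc(OC)c(OC)c(OC)c2)n(-c2ccc(OC)cc2)n1`: 56%
Compound 2 `CCNC(=O)c1nc(-c2cc(OC)c(OC)c(OC)c2)n(-c2ccc(OC)cc2)n1`: 60%
Compound 3 `COc1ccc(-n2nc(C(=O)Nc3ccccc3C)nc2-c2cc(OC)c(OC)c(OC)c2)cc1`: 19%

Of the compounds shown here, three have been tested in a functional assay on the whole organism for inhibition, with Rattus norvegicus as the target, read by paw edema, with stated times of 30 min and 1 h, at a dose of 0.28 mmol/kg by the oral route; a higher number here means more inhibition at the dose given (going by the name of the read-out), a lower number less inhibition. Compound 1 gives 56% and compound 2 gives 60%; the step of a number 4 percentage points higher from compound 1 to compound 2 (within the scatter) separates them. Compound 3 gives 19% and stands lowest of the three. The drops a number 37 percentage points lower from compound 1 to compound 3 (beyond the scatter) and a number 41 percentage points lower from compound 2 to compound 3 (beyond the scatter) both come with an aryl group taking the place of a small alkyl group on the amide-type nitrogen.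

Compound 4 `COc1ccc(-n2nc(C(=O)Nc3cccc(F)c3)nc2-c2cc(OC)c(OC)c(OC)c2)cc1` is not yet measured. It differs from compound 3 by 3-fluorophenyl in place of 2-methylphenyl on an amide-type nitrogen. Going by the values given here, no measured step compares one aryl group with another on this nitrogen; the two large steps concern alkyl against aryl only and so do not bear directly on this change. Since compound 3 already carries an aryl amide, compound 4 is expected to stay close to it, with a step of a number 3 percentage points higher from compound 3 to compound 4 (within the scatter) inside the scatter. Compound 4 is therefore estimated at 22%, ranging from 5% to 40%.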

Compound 4, a percentage reported as inhibition, in the whole organism at one dose (the size of the read-out at that dose, not a potency): 48%
Beside the measured number, compound 4's estimate is 26 percentage points below it; the measured number lies above the stated range.
By their numbers in this assay, from the lowest: compound 3; then compounds 4, 1 and 2 (each within the scatter of the next, the first and the last beyond it).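

In this assay, the aryl amides do not all behave alike: with an aryl group kept on the amide-type nitrogen, the change from 2-methylphenyl to 3-fluorophenyl gives a number 29 percentage points higher from compound 3 to compound 4 (beyond the scatter), so the low value of compound 3 cannot be read as belonging to every aryl amide. Set against the alkyl amides, the 3-fluorophenyl amide gives a number 8 percentage points lower from compound 1 to compound 4 (within the scatter) for the methyl comparison but a number 12 percentage points lower from compound 2 to compound 4 (beyond the scatter) for the ethyl comparison, so an aryl group at this position can retain much of the read-out. Nothing measured here explains the difference between the two aryl groups.

The change alters both the substituent and its place on the ring, so the effect of each remains unseparated. A plain phenyl, 2-fluorophenyl or 3-methylphenyl amide would be needed to tell them apart.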